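The compounds below may be only part of what the source reports. "The series", "measured", "known", "first", "only" and "open" are said of these compounds alone.

Compound 2 `COc1ccc(S(=O)(=O)NCCN2CCC(CCC(=O)c3cc(Cl)c(N)cc3OC)CC2)cc1OC` gives 8.2 nM in an assay on brain for displacement of a labelled ligand from 5-hydroxytryptamine receptor 4 (Cavia porcellus), with a stated time of 30 min, in the presence of a further agent that is not named here; on this read-out lower numbers stand for stronger inhibition and higher numbers for weaker inhibition. Among the three compounds measured there it holds the highest number: compound 1 `COc1cc(N)c(Cl)cc1C(=O)CCC1CCN(CCNS(=O)(=O)c2ccc3c(c2)NC(=O)CO3)CC1` gives 6.2 nM, and the step of a 1.3-fold higher number from compound 1 to compound 2 (0.12 log units; within the scatter) lies within the scatter, while compound 3 `COc1cc(N)c(Cl)cc1C(=O)CCC1CCN(CCNS(=O)(=O)c2ccc(OC)c(N3CCN(C)CC3)c2)CC1` gives 3.46 nM, the step of a 2.4-fold lower number from compound 2 to compound 3 (0.37 log units; beyond the scatter) being modest but beyond the scatter.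

Compound 4 `COc1cc(N)c(Cl)cc1C(=O)CCC1CCN(CCNS(=O)(=O)c2ccc(NC(C)=O)cc2)CC1` differs from compound 2 in a single place: 4-acetamidophenyl in place of 3,4-dimethoxyphenyl on a sulfonyl sulfur. Among the measured compounds shown here, two measured steps bear on this. The exchange of one aryl group for another on the same sulfonyl sulfur, from compound 1 to compound 2, moved the number only within the scatter. The change of one substituent on that aryl ring, from compound 2 to compound 3, moved it modestly. Together they suggest that the aryl group on the sulfonyl sulfur can be varied with small effect in this assay, and compound 4 is therefore expected to sit near compound 2, with a 1.2-fold lower number from compound 2 to compound 4 (0.07 log units; within the scatter) foreseen as a step within the scatter.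

Compound 4 is thus estimated to give 7 nM in this assay, within a range from 2.5 nM to 20 nM.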

Compound 4, inhibition constant: 7.7 nM
The estimate for compound 4 lay 1.1-fold (0.04 log units) below the measured number; the range from low to high includes it.
By their numbers in this assay, from the lowest: compounds 3, 1, 4 and 2 (each within the scatter of the next, the first and the last beyond it).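

In this assay, the exchange of 3,4-dimethoxyphenyl for 4-acetamidophenyl on the sulfonyl sulfur, a 1.1-fold lower number from compound 2 to compound 4 (0.03 log units; within the scatter), puts a group with 1 hydrogen-bond donor in place of one with none and leaves the number within the scatter. The comparison with the group of compound 1, which has a second six-membered ring that 4-acetamidophenyl lacks, gives the same picture, a 1.2-fold higher number from compound 1 to compound 4 (0.09 log units; within the scatter), so three different aryl groups at this position now lie within the scatter of one another, while compound 3 stands apart from compound 2 alone. No measurement shown accounts for this similarity.

The compounds shown leave open how a carboxylic acid or a primary amine on this aryl ring would read. They also leave open whether the aryl ring is needed at all, as a plain butyl chain on the sulfonyl sulfur would test.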